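Phenyl in Place of Thiophen-2-yl on a Shared Core

The compounds below may be only part of what the source reports. "The series", "measured", "known", "first", "only" and "open" are said of these compounds alone.

Compound 1 `Cn1cccc1-c1cc(-c2cccs2)[nH]c(=O)c1C#N` was tested in a functional assay on HOP-92 cells (Homo sapiens) for inhibition, read by sulforhodamine B assay, with a stated time of 48 h (on this read-out lower numbers stand for stronger inhibition of growth and higher numbers for weaker inhibition of growth), where compound 1 gives 10000 nM. Among the two plain numbers shown, that is the higher one; compound 3 `COc1ccc(-c2cc(-c3cccn3C)c(C#N)c(N)n2)cc1OC`, which in this assay gives 5130 nM, sits a short distance away, within the usual scatter, so the two cannot be ordered against each other. Compound 2 `CC1CCCc2c1[nH]c(=O)c(C#N)c2-c1cccn1C` reached only a limit of the assay in this assay, recorded as > 100000 nM; the limit of > 100000 nM in this assay, at which 1 of the 3 values shown sits, describes that limit. Compound 4 `Cn1cccc1-c1cc(-c2ccccc2)[nH]c(=O)c1C#N` is the next compound to be measured in this assay. It differs from compound 1 in one place: phenyl in place of thiophen-2-yl on an aromatic carbon. For the measured compounds named here, no step between measured compounds in this set shows how such a replacement acts on the shared core, so the expectation rests on the structural change alone. An expected step of a 1.2-fold higher number from compound 1 to compound 4 (0.08 log units; within the scatter) is therefore put forward, no larger than the scatter and in no settled direction. For compound 4, an estimated value of 12000 nM in this assay is given, expected to lie between 4000 nM and 40000 nM.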

Compound 4, concentration for 50% growth inhibition: 110 nM
The estimate for compound 4 lay 110-fold (2.04 log units) above the measured number, and the stated range ends above it.
By their numbers in this assay, from the lowest: compound 4; then compounds 3 and 1 (each within the scatter of the next). At a limit, above all of these: compound 2.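

In this assay the exchange of thiophen-2-yl for phenyl gave a 91-fold lower number from compound 1 to compound 4 (1.96 log units; beyond the scatter) and so showed that this aromatic carbon, next to the ring nitrogen and para to the cyano group, is highly sensitive to the ring it carries. For the compounds shown here, the earlier compounds offered no step between compounds differing in one place, so this is the first direct reading of any position on the shared core. No measurement shown here bears on why the step is so large.

On these data alone, whether the gain follows from the six-membered ring itself or from the loss of the sulfur atom remains open. Also open, as far as these compounds go, is how a furan-2-yl, a pyridin-3-yl or a phenyl carrying a methoxy group or a fluorine would read at this position.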